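The source may report more compounds than this note shows. Statements on the series, on what has been measured and on what is new or still open speak of the compounds shown alone.

Values so far (a functional assay on NCI-H460 cells (Homo sapiens) for inhibition, read by MTT assay, with a stated time of 72 h; a higher number here means a weaker inhibitor, a lower number a stronger inhibitor):
compound 1 `COc1cc(NC(C)CCCNC(=O)NNC(=O)Nc2ccc(C(F)(F)F)cc2)c2ncccc2c1` gives 12000 nM
compound 2 `COc1cc(NC(C)CCCNC(=O)NNC(=O)Nc2ccc(Br)cc2)c2ncccc2c1` gives 27000 nM
compound 3 `COc1cc(NC(C)CCCNC(=O)Nc2cc(C(F)(F)F)cc(C(F)(F)F)c2)c2ncccc2c1` gives 8300 nM

Of these three, compound 2 has the highest number, which makes it the weakest inhibitor so far, and compound 1 lies closest to it. The next compound, still unmeasured, is compound 4 `COc1cc(NC(C)CCCNC(=O)NNC(=O)Nc2cccc(Cl)c2)c2ncccc2c1`. It keeps all of compound 2 except one group (3-chlorophenyl in place of 4-bromophenyl on an amide-type nitrogen), with 3-chlorophenyl in place of 4-bromophenyl on an amide-type nitrogen.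

Among the compounds with values here, only one measured step changes a group at this end of the molecule (a 2.3-fold higher number from compound 1 to compound 2 (0.35 log units; beyond the scatter)), with bromo in place of trifluoromethyl on an aromatic carbon. That step was modest and involved a different pair of groups, so it offers only a rough guide to size. Compound 3 differs from compound 2 in more than one place and gives no clean comparison. In this assay a change no larger than that modest step is therefore expected, most likely none beyond the scatter. The expected change is a 1.4-fold lower number from compound 2 to compound 4 (0.13 log units; within the scatter) (an estimate). Compound 4 is estimated at 20000 nM (expected range 9000 nM to 45000 nM).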

Compound 4, half-maximal inhibitory concentration: 32000 nM
Beside the measured number, compound 4's estimate is 1.6-fold (0.20 log units) below it; the measured number falls inside the stated range.
By their numbers in this assay, from the lowest: compounds 3 and 1 (each within the scatter of the next); then compounds 2 and 4 (each within the scatter of the next).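

In this assay, exchanging 4-bromophenyl for 3-chlorophenyl on the amide-type nitrogen gives a 1.2-fold higher number from compound 2 to compound 4 (0.07 log units; within the scatter) and so leaves these two groups indistinguishable in this assay, even though the halogen and the number in the group's name both change. The 4-(trifluoromethyl)phenyl group of compound 1 remains apart from 3-chlorophenyl, with a 2.7-fold higher number from compound 1 to compound 4 (0.43 log units; beyond the scatter) being a modest step, so among these three groups it alone gives a number separated from both others. Nothing measured here explains these differences.

The effects of the halogen and of its position stay tangled, and separating them would take a pair such as 3-bromophenyl and 3-chlorophenyl. Also open, as far as these compounds go, is how an amine, a carboxylic acid or a methoxy group on this phenyl ring would behave.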